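The compounds below may be only part of what the source reports. "The series", "measured", "known", "first", "only" and "open" are said of these compounds alone.

Working notes on the series. The shared core, as in compound 1 `COc1ccc2c(CN(C)C)cn(CCNC(C)=O)c2n1`, carries a 2-acetamidoethyl group on the ring nitrogen and a methoxy group on the six-membered ring; affinity is followed in an assay on HEK293 cells for displacement of a labelled ligand from melatonin receptor type 1B (Homo sapiens); on this read-out higher numbers stand for weaker inhibition and lower numbers for stronger inhibition. Compound 1 gives > 10000 nM in this assay, and that figure is a limit of the assay, not a number, so compound 1 stands at the limit of > 10000 nM in this assay, at which 1 of the 2 values shown sits, rather than at a measured point. Within the data shown here, compound 2 `COc1ccc2c(CN3CCC(C(=O)c4ccc(F)cc4)CC3)cn(CCNC(C)=O)c2n1`, which bears a (4-fluorobenzoyl)piperidinylmethyl group in the same place, gives 7440 nM in this assay; the two values together show only that both compounds sit in the weak region of the read-out. Among the measured compounds shown here, no step between measured compounds is available here.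

Compound 3 `COc1ccc2c(I)cn(CCNC(C)=O)c2n1` has not yet been measured. It differs from compound 1 in one place: iodo in place of (dimethylamino)methyl on an aromatic carbon. For the measured compounds named here, with no measured step to lean on, the step from compound 1 to compound 3 is expected to be a gain, that is a lower number, of moderate size, beyond the scatter, an at least 5.0-fold lower number from compound 1 to compound 3 (0.69 log units; beyond the scatter). Compound 3 is accordingly expected to give about 2000 nM in this assay, with a plausible range from 300 nM to 10000 nM.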

Compound 3, inhibition constant: 5 nM
Beside the measured number, compound 3's estimate is 400-fold (2.60 log units) above it, outside the stated range (below it).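

In this assay, the aromatic carbon two ring bonds from the ring nitrogen now has a measured point in the strong region of the read-out: iodo in place of (dimethylamino)methyl gives an at least 2000-fold lower number from compound 1 to compound 3 (3.30 log units; beyond the scatter). The weak values seen so far therefore do not belong to the shared core as such, since this single change on this carbon moves the series from the weak region to the strong one. The size of the step can be read only as a bound, because the value of compound 1 is a limit of the assay and not a number: the limit of > 10000 nM in this assay, at which 1 of the 3 values shown sits.

Going by these compounds, the pair does not separate what iodo contributes from what the loss of (dimethylamino)methyl contributes, so it remains open whether the strong value comes from the entering group or from the leaving one. Plain hydrogen, chloro, bromo or methyl on the same aromatic carbon would bear on that question, as would a primary amine for the side of the group that leaves.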